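The source may hold more compounds than are shown below. What is called first, only, known or untested is meant among the compounds shown, and "the series" means these compounds.

Compound 2 `Cn1c(=O)cnn(CCCCN2CCN(c3c(Br)cccc3C#N)CC2)c1=O` bears a 2-bromo-6-cyanophenyl on an amine nitrogen in a ring of the shared core. In an assay for displacement of a labelled ligand from Adrenergic receptor alpha-1 (Homo sapiens) (on this read-out higher numbers stand for weaker inhibition and lower numbers for stronger inhibition), compound 2 gives 450 nM. Compound 1 `Cn1c(=O)cnn(CCCCN2CCN(c3ccccc3OCCCF)CC2)c1=O` gives 280 nM in this assay, within the scatter of compound 2. Compound 3 `Cn1c(=O)cnn(CCCCN2CCN(c3ccccc3S)CC2)c1=O` reaches only (the limit of > 10000 nM in this assay, at which 1 of the 3 values shown sits); in this assay compound 3 gives > 10000 nM, a limit rather than a number. The steps of an at least 35-fold higher number from compound 1 to compound 3 (1.55 log units; beyond the scatter) and an at least 22-fold higher number from compound 2 to compound 3 (1.34 log units; beyond the scatter) both end at that limit. Compound 4 `Cn1c(=O)cnn(CCCCN2CCN(c3cccc(Br)n3)CC2)c1=O` differs from compound 2 by 6-bromopyridin-2-yl in place of 2-bromo-6-cyanophenyl on an amine nitrogen in a ring. Within the data shown here, only the step ending in compound 3 touches the same nitrogen, and it installs an unrelated group, so it says little here. A step within the scatter is expected, a 1.1-fold higher number from compound 2 to compound 4 (0.05 log units; within the scatter). Compound 4 is estimated at 500 nM, between 150 nM and 2000 nM.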

Compound 4, inhibition constant: > 10000 nM
Compound 4 ended at the assay's limit; the forecaster's own chance of this, stated with the estimate: 10%; middle value at least 20-fold (1.30 log units) from the limit.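

In this assay, 6-bromopyridin-2-yl in place of 2-bromo-6-cyanophenyl on the amine nitrogen in a ring is far from a neutral exchange, giving an at least 22-fold higher number from compound 2 to compound 4 (1.34 log units; beyond the scatter). A bromine-bearing six-membered aromatic ring at this position is therefore not enough to keep the value seen for compound 2. Compound 4, like compound 3, stands at a limit and not at a number, so the step between them cannot be read: the limit of > 10000 nM in this assay, at which 2 of the 4 values shown sit.

The compounds shown leave open whether the ring nitrogen of the pyridine or the loss of the nitrile accounts for this step. A plain 2-bromophenyl or a 6-bromo-2-cyanopyridinyl group at this nitrogen would separate the two changes.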